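The compounds below may be only part of what the source reports. "The series", "measured", "known", "first", "only" and "open" are said of these compounds alone.

Three compounds share one core and differ only in the group on a saturated chain carbon bound to a carbonyl carbon. Compound 1 `Cn1cncc1CN1CC(N(CC2CCN(C(=O)CNC(=O)OC(C)(C)C)CC2)S(=O)(=O)c2ccccn2)Cc2cc(C#N)ccc21` gives 0.5 10^-6 cm/s in an ADME assay on Caco-2 cells (Homo sapiens) for permeability, in the apical to basolateral direction; on this read-out higher numbers stand for higher permeability and lower numbers for lower permeability. Compound 2 `Cn1cncc1CN1CC(N(CC2CCN(C(=O)CC(C)(C)C)CC2)S(=O)(=O)c2ccccn2)Cc2cc(C#N)ccc21` gives 0.5 10^-6 cm/s in this assay, and compound 3 `CCCC(=O)N1CCC(CN(C2Cc3cc(C#N)ccc3N(Cc3cncn3C)C2)S(=O)(=O)c2ccccn2)CC1` gives 0.5 10^-6 cm/s. The steps among them are no change at the digits printed from compound 1 to compound 2 (within the scatter), no change at the digits printed from compound 1 to compound 3 (within the scatter) and no change at the digits printed from compound 2 to compound 3 (within the scatter), so compound 3 stands level with compounds 1 and 2. Compound 4 `Cc1noc(C)c1CN(C1Cc2cc(C#N)ccc2N(Cc2cncn2C)C1)S(=O)(=O)c1ccccn1` differs from compound 3 in another place: 3,5-dimethyl-1,2-oxazol-4-yl in place of 1-(propylcarbonyl)piperidin-4-yl on a saturated chain carbon bound to a sulfonamide nitrogen. Going by the values given here, none of the measured steps touches this place; they show only that altering the group on the carbonyl-bound carbon, which sits within the part that leaves, left this assay unchanged. Among the compounds with values here, with no measured step bearing directly on this exchange, the expectation rests on the shared core alone, and a small rise is expected, a 2.4-fold higher number from compound 3 to compound 4 (0.38 log units; beyond the scatter), with wide uncertainty in both directions. Compound 4 is therefore estimated at 1.2 10^-6 cm/s, between 0.4 10^-6 cm/s and 4 10^-6 cm/s.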

Compound 4, apparent permeability: 8 10^-6 cm/s
Beside the measured number, compound 4's estimate is 6.7-fold (0.82 log units) below it; measured number above the stated range.
By their numbers in this assay, from the lowest: compounds 1, 2 and 3 (each within the scatter of the next); then compound 4.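

The earlier compounds shown here altered only the group on the carbonyl-bound carbon and left this assay unchanged, whereas exchanging the whole group on a saturated chain carbon bound to a sulfonamide nitrogen gives a 16-fold higher number from compound 3 to compound 4 (1.20 log units; beyond the scatter), a large step. This place can therefore move the read-out, which the first three compounds could not show. The exchange puts 3,5-dimethyl-1,2-oxazol-4-yl, a five-membered aromatic ring, where 1-(propylcarbonyl)piperidin-4-yl, a six-membered non-aromatic ring with a carbonyl outside it, stood, and nothing measured here explains the rise.

Ring size, aromatic character and the loss of the carbonyl all change together in this single step, so the compounds shown cannot separate them. A phenyl ring, or a piperidin-4-yl without its propylcarbonyl group, at this place would help to pull these changes apart.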